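The compounds below may be only part of what the source reports. "The series", "measured", "known", "first", "only" and "open" are said of these compounds alone.

Working notes on the series. In a physicochemical assay for permeability, using PAMPA (on this read-out lower numbers stand for lower permeability and higher numbers for higher permeability), compound 1 `Cc1oc(-c2ccc(F)cc2)nc1CN1CCC(C(=O)NCCCN2C[C@H](C)C[C@H](C)C2)CC1` reads "not determined" (no result reported), so it offers no comparison. For the measured compounds named here, compound 2 `Cc1ccc(-c2nc(CN3CCC(C(=O)NCCCN4C[C@H](C)C[C@H](C)C4)CC3)c(C)o2)c(C)c1` gives 353 10^-6 cm/s, the only number available, which leaves it with no rank among measured compounds. Compound 3 `Cc1cc(C)cc(-c2nc(CN3CCC(C(=O)NCCCN4C[C@H](C)C[C@H](C)C4)CC3)c(C)o2)c1` has not yet been measured. Going by the values given here, it is an isomer of compound 2, and the single change is 3,5-dimethylphenyl in place of 2,4-dimethylphenyl on an aromatic carbon, with 3,5-dimethylphenyl in place of 2,4-dimethylphenyl on an aromatic carbon. Among the compounds with values here, no measured step between compounds shows what such a change does in this assay, so the expectation rests on the value of compound 2 alone. The expected change is a 1.0-fold lower number from compound 2 to compound 3 (0.00 log units; within the scatter), with no step beyond the scatter and no preferred direction. Compound 3 is expected at 350 10^-6 cm/s, with an estimated range of 170 10^-6 cm/s to 700 10^-6 cm/s.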

Compound 3, apparent permeability: 864 10^-6 cm/s
Estimate against measurement, compound 3: 2.5-fold (0.39 log units) below, and the stated range ends below it.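

For the compounds shown here, replacing 2,4-dimethylphenyl with 3,5-dimethylphenyl on the aromatic carbon of the five-membered ring gives the first measured step at this position: in this assay there is a 2.4-fold higher number from compound 2 to compound 3 (0.39 log units; beyond the scatter). Compound 1 has no result and could not show that this position affects the read-out. The leaving and entering groups match in heavy atoms, aromatic ring and counted donors and acceptors, so this step separates two isomers with the same atoms, joined differently, and nothing shown accounts for the difference.

A single step cannot show whether the number follows the placement of the methyl groups in general. Also open, as far as these compounds go, is how the read-out would respond to a methoxy group on the phenyl ring, or to a pyridine ring in place of the phenyl ring.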